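From chloro to trifluoromethyl in compound 3

The compounds below may be only part of what the source reports. "The series", "measured", "known", "first", "only" and "open" are said of these compounds alone.

Of the compounds shown here, three built on a shared core have been measured so far. In a physicochemical assay for solubility, at pH 7.4 (on this read-out lower numbers stand for lower solubility and higher numbers for higher solubility), compound 1 `O=C(N[C@H]1CN(S(=O)(=O)c2ccccc2)C[C@@H]1C(=O)N[C@H]1CCCNC1)c1cc(-c2ccccc2)on1` gives 94000 nM and compound 2 `Cc1nc(-c2cccc(C(F)(F)F)c2)sc1C(=O)N[C@H]1CN(S(=O)(=O)c2ccccc2)C[C@@H]1C(=O)N[C@H]1CCCNC1` gives 112000 nM while compound 3 `Cc1oc(-c2ccc(Cl)cc2)nc1C(=O)N[C@H]1CN(S(=O)(=O)c2ccccc2)C[C@@H]1C(=O)N[C@H]1CCCNC1` gives 15000 nM on the same scale. Compound 3 is thus the lowest of the three, and its gaps to compound 1 and to compound 2 both lie beyond the usual scatter of repeated measurements.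

Compound 4 `Cc1oc(-c2ccc(C(F)(F)F)cc2)nc1C(=O)N[C@H]1CN(S(=O)(=O)c2ccccc2)C[C@@H]1C(=O)N[C@H]1CCCNC1` is compound 3 with a single swap, 4-chlorophenyl to 4-(trifluoromethyl)phenyl: trifluoromethyl in place of chloro on an aromatic carbon para to a large group. For the measured compounds named here, no two measured compounds differ in only one place, so the data hold no direct example of this swap. Compound 3 differs from compound 2 in more than one group, so the trifluoromethyl group that compound 2 carries cannot be credited with the value of compound 2 (112000 nM) on its own. The expectation therefore stays close to compound 3 (15000 nM) as its only anchor. In this assay a slight downward move is expected (a 1.3-fold lower number from compound 3 to compound 4 (0.10 log units; within the scatter)) and it is not expected to go beyond the scatter. Compound 4 is estimated at 12000 nM with an expected range from 5000 nM to 30000 nM in this measurement.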

Compound 4, solubility: 13000 nM
Estimate against measurement, compound 4: 1.1-fold (0.03 log units) below; the measured number falls inside the stated range.
By their numbers in this assay, from the lowest: compounds 4 and 3 (each within the scatter of the next); then compounds 1 and 2 (each within the scatter of the next).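

In this assay, the step of a 1.2-fold lower number from compound 3 to compound 4 (0.06 log units; within the scatter) lies within the scatter, so on an aromatic carbon of this six-membered ring, para to a large group, the assay does not separate trifluoromethyl from chloro. For the compounds shown here, this is the first pair that differs in one place, and it gives a direct reading of a single change that compounds 1, 2 and 3 could not give among themselves. The swap brings in a larger group by heavy-atom count, with no ring, hydrogen-bond donor, hydrogen-bond acceptor or net charge on either side, yet no step beyond the scatter appears, and nothing available here speaks to what lies behind this result.

The compounds shown leave open how a group of a different kind in this place, such as an amine or a carboxylic acid, would read in this assay. Going by these compounds alone, they also leave open whether trifluoromethyl in place of chloro would give a step of similar size on a different core, as this single pair is the only example of the swap.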